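Fluorine in Place of a Nitrile: Expected Antiproliferative Potency

The source may report more compounds than this note shows. Statements on the series, on what has been measured and on what is new or still open speak of the compounds shown alone.

Measured compounds:
Compound 1 `Clc1ccc(-c2cc(-c3ccccc3)c3cc(Br)ccc3n2)cc1` gives 269000 nM in a functional assay on Hep2C cells (Homo sapiens) for antiproliferative activity, read by MTT assay, with a stated time of 24 h; on this read-out lower numbers stand for stronger inhibition and higher numbers for weaker inhibition.
Compound 2 `Brc1ccc2nc(-c3ccco3)cc(-c3ccccc3)c2c1` gives 102000 nM in this assay.
Compound 3 `N#Cc1ccc(-c2cc(-c3ccccc3)c3cc(Br)ccc3n2)cc1` gives 98800 nM in this assay.

Compound 3 has the lowest number of the three, yet its gap to compound 2 lies within the scatter, so the two cannot be separated; only compound 1 stands clearly apart, with a modest step of a 2.7-fold lower number from compound 1 to compound 3 (0.43 log units; beyond the scatter).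

Compound 4 `Fc1ccc(-c2cc(-c3ccccc3)c3cc(Br)ccc3n2)cc1` is the next member of the series. It differs from compound 3 by fluoro in place of cyano on an aromatic carbon.

Among the measured compounds shown here, the one measured step that bears on this change is a 2.7-fold lower number from compound 1 to compound 3 (0.43 log units; beyond the scatter), where a cyano replaced a chloro at the same place and gave a modest lowering. Fluoro, like chloro, is a halogen, and the data hold nothing else on this position. The change from compound 3 to compound 4 therefore looks like a partial reversal of that step, and a modest rise in the number, rather than a fall, is expected, though a result within the scatter cannot be ruled out.

For compound 4 the expected step is a 1.8-fold higher number from compound 3 to compound 4 (0.26 log units; within the scatter). The estimate for compound 4 in this assay is 180000 nM, with a range from 80000 nM to 400000 nM.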

Compound 4, half-maximal inhibitory concentration: 5000 nM
For compound 4 the middle estimate is 36-fold (1.56 log units) above the measured one; measured number below the stated range.
By their numbers in this assay, from the lowest: compound 4; then compounds 3 and 2 (each within the scatter of the next); then compound 1.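

In this assay, the group on this six-membered aromatic ring, para to a large group, turns out to matter far more than the earlier modest steps suggested: fluoro in place of cyano gives a 20-fold lower number from compound 3 to compound 4 (1.30 log units; beyond the scatter) and fluoro in place of chloro gives a 54-fold lower number from compound 1 to compound 4 (1.73 log units; beyond the scatter), so two halogens at the same place do not behave alike here. The 4-fluorophenyl group also clearly beats furan-2-yl, with a 20-fold lower number from compound 2 to compound 4 (1.31 log units; beyond the scatter), which leaves compound 4 as the most potent of the four, well apart from the rest, and shows that the fluoro group, not simply the presence of a halogen, goes with the low number. Nothing available here explains why fluoro stands so far from chloro and cyano.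

Going by these compounds, it remains open whether this drop is unique to fluoro or would also appear with another small group at the same place, such as a methoxy group, an amine or a trifluoromethyl group. It is also unclear whether moving the fluoro elsewhere on the ring, or adding a second one, would keep the gain.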